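This account rests on a few compounds, and the source may have more. Where it says the series, first, only, none or still open, it means among the compounds named here.

Compound 1 `Nc1ccccc1NC(=O)CCCNCC(=O)Nc1cccc(Cl)c1`: > 100000 nM, a limit
Compound 2 `Nc1ccccc1NC(=O)CCCNCC(=O)Nc1ccc(Br)cc1`: > 100000 nM, a limit

In a functional assay on HCT-116 cells (Homo sapiens) for inhibition, read by MTT assay, with a stated time of 2 days (on this read-out higher numbers stand for lower toxicity in this test and lower numbers for higher toxicity in this test), compound 2 gives > 100000 nM, which is a limit of the assay and not a number. Compound 1 gives > 100000 nM, and this too is a limit. All the data so far therefore come down to the limit of > 100000 nM in this assay, at which 2 of the 2 values shown sit.

Compound 3 `Nc1ccccc1NC(=O)CCCNCC(=O)Nc1cccc([N+](=O)[O-])c1` has not yet been measured. Its difference from compound 2 is 3-nitrophenyl in place of 4-bromophenyl on an amide-type nitrogen.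

Among the measured compounds shown here, the only measured step that bears on this is a step that the two limits leave unreadable from compound 1 to compound 2, which also exchanges one substituted phenyl for another on that nitrogen. Its size cannot be read, so it offers no measure for the new exchange. Given that compound 2 stands at > 100000 nM, a limit, no step beyond the scatter is expected in this assay, although a true number remains possible. The expected change is a number no higher from compound 2 to compound 3 (the limit leaves the size open). For compound 3 the estimated value is 100000 nM, with an expected range from 40000 nM to 200000 nM.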

Compound 3, concentration lethal to 50% of the cells: > 100000 nM
Compound 3 ended at the assay's limit (the forecaster's own chance of this, stated with the estimate: 75%); the middle value sits exactly at the limit.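

In this assay compound 3 gives > 100000 nM as a limit and not a number. Among the compounds shown here, no step among compound 1, compound 2 and compound 3 can be read, since all three stand at one reading: the limit of > 100000 nM in this assay, at which 3 of the 3 values shown sit. The compounds shown leave open whether any of the three has a true value in this assay and how such values would compare.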